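This account rests on a few compounds, and the source may have more. Where it says the series, first, only, none or still open, it means among the compounds named here.

Of the compounds shown here, two have been measured in a functional assay on PC-12 cells (Rattus norvegicus) for cytotoxicity, read by MTT assay, with stated times of 3 h and 2 h, tested at 1 uM (a higher number here means a stronger effect of the compound at the concentration tested, a lower number a weaker effect), so far. Compound 1, `Cc1cc(=O)oc2cc(OCCCn3cc(CNC(=O)CCCCC4CCSS4)nn3)ccc12`, gives 54.5% in this assay. Compound 2, `O=C(CCCCC1CCSS1)NCc1cn(CCCOc2ccc3cc(C(=O)O)c(=O)oc3c2)nn1`, gives 52.1% in this assay, and its number and that of compound 1 lie within the scatter of each other, so neither can be called the stronger. Compound 3, `O=C(CCCCC1CCSS1)NCc1cn(CCCOc2ccc3cc(-c4ccc(Cl)c(Cl)c4)c(=O)oc3c2)nn1`, differs from compound 2 by 3,4-dichlorophenyl in place of carboxy on an aromatic carbon. Going by the values given here, no measured pair shows what this kind of change does, so the expected step in this assay is small, with no direction beyond the scatter. Compound 3 is therefore expected to show 55%, in a range from 35% to 75%, which would mean a step of a number 2.9 percentage points higher from compound 2 to compound 3 (within the scatter).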

Compound 3, a percentage reported as activity, at one concentration (the size of the read-out at that concentration, not a potency): 42.4%
Estimate against measurement, compound 3: 12.6 percentage points above; low and high end bracket the measured number.
By their numbers in this assay, from the lowest: compounds 3, 2 and 1 (each within the scatter of the next, the first and the last beyond it).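

In this assay there is a number 9.7 percentage points lower from compound 2 to compound 3 (within the scatter) when 3,4-dichlorophenyl stands in place of carboxy on this aromatic carbon. This position therefore takes a group with a whole extra aromatic ring and no hydrogen-bond donor without a step that clears the scatter, something compounds 1 and 2 alone could not show. Nothing available gives a reason for the size of this step. As far as these compounds go, whether a plain phenyl, an amine or a methyl ester on this carbon would give a step beyond the scatter remains open, as does what the two chlorine atoms contribute.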